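Notes on the ester oxygen substituent: compounds 1 to 4

The source may report more compounds than this note shows. Statements on the series, on what has been measured and on what is new or still open speak of the compounds shown alone.

Compound 1 `COC(=O)NS(=O)(=O)c1sc(CC(C)C)cc1-c1cccc(Cn2ccnc2)c1` gives 400 nM in an assay on HEK293 cells for displacement of a labelled ligand from Type-2 angiotensin II receptor (Homo sapiens), read by scintillation counting, with a stated time of 240 min; on this read-out lower numbers stand for stronger inhibition and higher numbers for weaker inhibition. Compound 2 `CC(C)Cc1cc(-c2cccc(Cn3ccnc3)c2)c(S(=O)(=O)NC(=O)OC(C)C)s1` gives 160 nM in this assay. Compound 3 `CC(C)Cc1cc(-c2cccc(Cn3ccnc3)c2)c(S(=O)(=O)NC(=O)OC2CCCC2)s1` gives 180 nM in this assay.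

Compound 3 holds the second highest of the three numbers in this assay. Its nearest neighbour is compound 2, with a 1.1-fold higher number from compound 2 to compound 3 (0.05 log units; within the scatter), so the two are not distinguishable; the furthest is compound 1, with a 2.2-fold lower number from compound 1 to compound 3 (0.35 log units; beyond the scatter).

Compound 4 `COCCOC(=O)NS(=O)(=O)c1sc(CC(C)C)cc1-c1cccc(Cn2ccnc2)c1` has not been measured. It differs from compound 3 in one place: 2-methoxyethyl in place of cyclopentyl on an oxygen next to a carbonyl group.

Within the data shown here, the steps that bear on this spot all start from the methyl of compound 1: a 2.5-fold lower number from compound 1 to compound 2 (0.40 log units; beyond the scatter) and a 2.2-fold lower number from compound 1 to compound 3 (0.35 log units; beyond the scatter), both modest, while a 1.1-fold higher number from compound 2 to compound 3 (0.05 log units; within the scatter) shows that isopropyl and cyclopentyl are not separated. Among the measured compounds shown here, no measured step puts a chain carrying an oxygen acceptor on this position, so the direction of the step in this assay is uncertain; the expected step is a 1.4-fold higher number from compound 3 to compound 4 (0.14 log units; within the scatter), which is a slight rise, and it may well fall within the scatter. Compound 4 is estimated at 250 nM in this assay, with a range from 120 nM to 550 nM.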

Compound 4, inhibition constant: 480 nM
For compound 4 the middle estimate is 1.9-fold (0.28 log units) below the measured one, within the range that was stated.
By their numbers in this assay, from the lowest: compounds 2 and 3 (each within the scatter of the next); then compounds 1 and 4 (each within the scatter of the next).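

In this assay the substituent on an oxygen next to a carbonyl group now gives a modest step upward, with a 2.7-fold higher number from compound 3 to compound 4 (0.43 log units; beyond the scatter) and a 3.0-fold higher number from compound 2 to compound 4 (0.48 log units; beyond the scatter) both beyond the scatter, so the lower numbers of the isopropyl and cyclopentyl compounds do not extend to 2-methoxyethyl. Among these compounds, measured against methyl, the same group gives a 1.2-fold higher number from compound 1 to compound 4 (0.08 log units; within the scatter) and the two compounds are not distinguishable, which leaves compound 2 and compound 3 as the only members of this short set that stand apart from compound 1. With cyclopentyl to 2-methoxyethyl, the ring goes and one hydrogen-bond acceptor enters in a single step, and no data on hand give a reason for the rise or assign it to either change.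

The compounds shown leave open whether the oxygen of the chain or the open chain itself accounts for the step, a question that a plain butyl chain or a tetrahydrofuranyl ring in this place would address. Also open, on these data alone, is how a terminal amine or a carboxylic acid on the chain would read.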